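A Single Methyl on a Compound 2 Scaffold

This account rests on a few compounds, and the source may have more. Where it says the series, first, only, none or still open, it means among the compounds named here.

Measured in a functional assay on HT-29 cells (Homo sapiens) for antiproliferative activity, read by WST assay, with a stated time of 3 days; on this read-out lower numbers stand for stronger inhibition of growth and higher numbers for weaker inhibition of growth:
- Compound 1 `Cc1ncsc1-c1ccc(CNC(=O)[C@@H]2C[C@@H](O)CN2C(=O)[C@@H](NC(=O)CCNCCCONC(=O)c2ccc(F)c(F)c2Nc2ccc(I)cc2F)C(C)(C)C)cc1`: 5000 nM
- Compound 2 `Cc1ncsc1-c1ccc(CNC(=O)[C@@H]2C[C@@H](O)CN2C(=O)[C@@H](NC(=O)CCCCCCCCCNCCCONC(=O)c2ccc(F)c(F)c2Nc2ccc(I)cc2F)C(C)(C)C)cc1`: 500 nM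

Compound 2 gives 500 nM, the lower of the two numbers, and its gap to compound 1, at 5000 nM, lies beyond the scatter. Compound 3 `Cc1ncsc1-c1ccc([C@H](C)NC(=O)[C@@H]2C[C@@H](O)CN2C(=O)[C@@H](NC(=O)CCCCCCCCCNCCCONC(=O)c2ccc(F)c(F)c2Nc2ccc(I)cc2F)C(C)(C)C)cc1` has not yet been measured. It departs from compound 2 in one place: methyl in place of hydrogen on a saturated chain carbon bound to an amide-type nitrogen and an aromatic carbon. Going by the values given here, the data hold no measured example of this change, so no step beyond the scatter is expected in this assay, and no direction is firmly favoured. The estimated step of a 1.3-fold lower number from compound 2 to compound 3 (0.10 log units; within the scatter) is therefore expected to stay small. Compound 3 is expected at 400 nM, with an estimated range of 130 nM to 1200 nM.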

Compound 3, concentration for 50% growth inhibition: 240000 nM
Compound 3: the middle estimate sits 600-fold (2.78 log units) below what was measured; measured number above the stated range.
By their numbers in this assay, from the lowest: compound 2; then compound 1; then compound 3.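

In this assay, going by these compounds alone, methyl in place of hydrogen on a saturated chain carbon bound to an amide-type nitrogen and an aromatic carbon gives a 480-fold higher number from compound 2 to compound 3 (2.68 log units; beyond the scatter) and so shows that this position, unchanged in the earlier compounds, is highly sensitive to substitution on this scaffold. The change adds only 1 heavy atom, with no ring, no hydrogen-bond donors or acceptors and no net charge, so a very small addition is enough to produce a large step in this read-out. Nothing available explains the size of this step.

The compounds shown leave open how an ethyl or hydroxymethyl group at this carbon would compare with methyl, and how methyl in the opposite configuration would behave. They also leave open whether the same methyl would give a step of similar size on the shorter chain of compound 1.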